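The compounds below may be only part of what the source reports. "The series", "measured", "known", "first", "only" and "open" are said of these compounds alone.

- compound 1 (`CC(C)C(=O)Oc1c(C(C)C)cc2c3c1OC(=O)[C@@]31CCCC(C)(C)[C@@H]1CC2`) – 105000 nM
- compound 2 (`CCCCC/C=C/C/C=C/CCCCCCCC(=O)Oc1c(C(C)C)cc2c3c1OC(=O)[C@@]31CCCC(C)(C)[C@@H]1CC2`) – 253000 nM

In an ADME assay on AGS cells (Homo sapiens) for cytotoxicity, read by neutral red uptake, with a stated time of 24 h (a lower number here means a stronger inhibitor, a higher number a weaker inhibitor), compound 1 has the lower of the two numbers, and compound 2 lies higher by more than the usual scatter. Compound 3 (`CC(C)c1cc2c3c(c1OC(=O)c1cccnc1)OC(=O)[C@@]31CCCC(C)(C)[C@@H]1CC2`) has not been measured yet. It differs from compound 1 by pyridin-3-yl in place of isopropyl on a carbonyl carbon. For the measured compounds named here, no measured step shows this change, so the only guide is the span from compound 1 (105000 nM) to compound 2 (253000 nM). In this assay a small step without a clear direction is expected, probably within the scatter. The expected change is small (a 1.1-fold higher number from compound 1 to compound 3 (0.06 log units; within the scatter)). Compound 3 is estimated at (120000 nM), with an expected range from 50000 nM to (280000 nM).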

Compound 3, half-maximal inhibitory concentration: 280000 nM
Estimate against measurement, compound 3: 2.3-fold (0.37 log units) below; measured number inside the range.
By their numbers in this assay, from the lowest: compound 1; then compounds 2 and 3 (each within the scatter of the next).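

In this assay, pyridin-3-yl in place of isopropyl on a carbonyl carbon gives a 2.7-fold higher number from compound 1 to compound 3 (0.43 log units; beyond the scatter). This shows that a ring at this position, not only the long chain of compound 2, goes with a number above that of compound 1, and compound 3 and compound 2 lie within the scatter of each other. No available measurement explains this shift. On these data alone, whether a plain phenyl ring, without the ring nitrogen of pyridin-3-yl, would give the same number remains open. So does the effect of an amine or a carboxylic acid on this acyl group.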